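Trifluoromethyl on the Benzyl Ring of Compound 1

The source may report more compounds than this note shows. Statements on the series, on what has been measured and on what is new or still open speak of the compounds shown alone.

Compound 1 `Nc1ncn(Cc2ccccc2)c2ncnc1-2` is the reference point. For the measured compounds named here, in an assay on isolated protein (adrenal medulla) for inhibition of Dopamine beta-hydroxylase (Bos taurus) (a higher number here means a weaker inhibitor, a lower number a stronger inhibitor), compound 1 gives 2 ug/mL, the lowest of the three numbers measured so far. Compound 2 `Nc1ncn(Cc2ccccc2Cl)c2ncnc1-2` gives 200 ug/mL, and compound 3 `Nc1ncn(Cc2ccccc2Br)c2ncnc1-2` gives 200 ug/mL. The steps of a 100-fold higher number from compound 1 to compound 2 (2.00 log units; beyond the scatter) and a 100-fold higher number from compound 1 to compound 3 (2.00 log units; beyond the scatter) were both large and beyond the scatter, while no change at the digits printed from compound 2 to compound 3 (within the scatter).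

Compound 4 `Nc1ncn(Cc2cccc(C(F)(F)F)c2)c2ncnc1-2` has not yet been measured; it differs from compound 1 by trifluoromethyl in place of hydrogen on an aromatic carbon. The two measured steps bear on it because a 100-fold higher number from compound 1 to compound 2 (2.00 log units; beyond the scatter) and a 100-fold higher number from compound 1 to compound 3 (2.00 log units; beyond the scatter) each show that a substituent on this ring raised the number sharply. The trifluoromethyl group, however, sits meta to a large group, a place not probed by compound 2 or compound 3, and the group itself is new, so the transfer is uncertain. A weakening is therefore expected, roughly a 10-fold higher number from compound 1 to compound 4 (1.00 log units; beyond the scatter), possibly milder than the halogen cases. Compound 4 is estimated at 20 ug/mL, within 3 ug/mL to 200 ug/mL.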

Compound 4, half-maximal inhibitory concentration: 20 ug/mL
For compound 4 middle estimate and measured number coincide at the digits printed; measured number inside the range.
By their numbers in this assay, from the lowest: compound 1; then compound 4; then compounds 2 and 3 (each within the scatter of the next).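

In this assay, trifluoromethyl meta to a large group gives a 10-fold higher number from compound 1 to compound 4 (1.00 log units; beyond the scatter), so the weakening seen on this ring is not confined to the place held by the chloro of compound 2 and the bromo of compound 3, nor to halogen atoms. This step is smaller than a 100-fold higher number from compound 1 to compound 2 (2.00 log units; beyond the scatter), but the group and its place both differ between those two changes, so the smaller size cannot be assigned to either one alone. Nothing available explains the weakening seen with trifluoromethyl.

The compounds shown leave open whether chloro or bromo meta to a large group would match this step, and how trifluoromethyl would fare in the place held by those halogens. They also leave open how a methoxy group, an amine or a carboxylic acid would behave meta to a large group.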